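This account rests on a few compounds, and the source may have more. Where it says the series, first, only, none or still open, it means among the compounds named here.

Measured compounds in an ADME assay on Nthy-ori 3-1 cells (Homo sapiens) for cytotoxicity, read by MTT assay, with a stated time of 10 days; on this read-out lower numbers stand for stronger inhibition of growth and higher numbers for weaker inhibition of growth:
compound 1 `Nc1ncnc2c1c(-c1cc(C3CC3)on1)nn2C1CCCCC1`: 32500 nM
compound 2 `CC(C)n1nc(-c2cc(-c3ccccc3)on2)c2c(N)ncnc21`: 5720 nM
compound 3 `CC(C)n1nc(-c2cc(C3CCCCC3)on2)c2c(N)ncnc21`: 4110 nM

Compound 1 gives the highest of the three numbers; compound 2 is its nearest neighbour and compound 3 the furthest, both gaps beyond the scatter. For the measured compounds named here, the only measured step, a 1.4-fold lower number from compound 2 to compound 3 (0.14 log units; within the scatter), concerns a group on an aromatic carbon, not the aromatic nitrogen, and is within the scatter. Compound 4 `CCCCCCCn1nc(-c2cc(C3CC3)on2)c2c(N)ncnc21` differs from compound 1 by heptyl in place of cyclohexyl on an aromatic nitrogen. Going by the values given here, no measured step touches that position, so nothing in the data points to a direction, and the account can only expect no change beyond the scatter in this assay. Compound 4 is therefore estimated at 32000 nM, between 12000 nM and 85000 nM, a step of a 1.0-fold lower number from compound 1 to compound 4 (0.01 log units; within the scatter) that is expected to be no more than scatter.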

Compound 4, concentration for 50% growth inhibition: 31600 nM
For compound 4 the middle estimate is 1.0-fold (0.01 log units) above the measured one; low and high end bracket the measured number.
By their numbers in this assay, from the lowest: compounds 3 and 2 (each within the scatter of the next); then compounds 4 and 1 (each within the scatter of the next).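

In this assay, the step of a 1.0-fold lower number from compound 1 to compound 4 (0.01 log units; within the scatter) shows that, on the aromatic nitrogen, heptyl, which has no ring, can take the place of the six-membered cyclohexyl ring with no change beyond the scatter. For the compounds shown here, the earlier step concerned an aromatic carbon, so this is the first reading at this position. No supporting measurement bears on this result. Still open, as far as these compounds go, is how a shorter chain, an amine or a carboxylic acid on this nitrogen would compare. From the compounds shown here alone, whether the same exchange would read alike with phenyl or cyclohexyl on the aromatic carbon also stays open.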